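The source may hold more compounds than are shown below. What is called first, only, known or untested is meant among the compounds shown, and "the series" means these compounds.

Measured compounds:
- Compound 1, `COc1cc(C2=NOC(COc3ccc(-c4nnnn4-c4cc(OC)c(OC)c(OC)c4)cc3N)C2)ccc1O`, gives 3620 nM in a functional assay on MDA-MB-231 cells (Homo sapiens) for cytotoxicity, read by MTT assay, with a stated time of 48 h; on this read-out lower numbers stand for stronger inhibition and higher numbers for weaker inhibition.
- Compound 2, `COc1ccc(F)c(C2=NOC(COc3ccc(-c4nnnn4-c4cc(OC)c(OC)c(OC)c4)cc3N)C2)c1`, gives 2830 nM in this assay.

Among the measured compounds shown here, compound 2 holds the lower of the two numbers, but its only neighbour is compound 1, and the step of a 1.3-fold lower number from compound 1 to compound 2 (0.11 log units; within the scatter) lies within the scatter, so the two compounds cannot be told apart on these data.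

Compound 3, `COc1cc(-n2nnnc2-c2ccc(OCC3CC(c4cccc(Cl)c4)=NO3)c(N)c2)cc(OC)c1OC`, has not yet been measured. It differs from compound 2 in one place: 3-chlorophenyl in place of 2-fluoro-5-methoxyphenyl on a carbon with a double bond to nitrogen.

For the measured compounds named here, one measured step bears on this change, because it also exchanges the aryl group on a carbon with a double bond to nitrogen: a 1.3-fold lower number from compound 1 to compound 2 (0.11 log units; within the scatter), which is within the scatter. Going by the values given here, with only this one comparison, no step beyond the scatter is expected for compound 3 in this assay, in either direction.

Compound 3 is therefore estimated at 3000 nM, with an expected range from 1200 nM to 7500 nM. This estimate corresponds to an expected step of a 1.1-fold higher number from compound 2 to compound 3 (0.03 log units; within the scatter).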

Compound 3, half-maximal inhibitory concentration: 2180 nM
For compound 3 the middle estimate is 1.4-fold (0.14 log units) above the measured one; measured number inside the range.
By their numbers in this assay, from the lowest: compounds 3, 2 and 1 (each within the scatter of the next).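

In this assay the change to 3-chlorophenyl brings a 1.3-fold lower number from compound 2 to compound 3 (0.11 log units; within the scatter) and, measured against 4-hydroxy-3-methoxyphenyl, a 1.7-fold lower number from compound 1 to compound 3 (0.22 log units; within the scatter) so neither step can be told apart from repeat-measurement noise. The new point is that this carbon of the five-membered ring now carries an aryl group with a chlorine and no hydrogen-bond acceptor, and with fewer heavy atoms than 2-fluoro-5-methoxyphenyl, yet all three compounds still read alike. Nothing measured here explains this similarity.

These three compounds are all substituted phenyl groups, so they leave open whether a different kind of group at this position would produce a step beyond the scatter. A phenyl ring bearing an amine or a carboxylic acid, or a saturated ring such as cyclohexyl, would test this.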